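The source may report more compounds than this note shows. Statements on the series, on what has been measured and on what is new or still open speak of the compounds shown alone.

Measured compounds:
compound 1, `COc1ccc(F)c([C@H]2CC[C@H](COc3cccc([C@@H](CC(=O)O)C4CC4)c3)CC2)c1`; compound 2, `COc1ccc(F)c([C@H]2CC[C@H](COc3cccc([C@H](C4CC4)[C@H](C)C(=O)O)c3)CC2)c1`.

In a functional assay on HEK293 cells for agonist activity at Free fatty acid receptor 1 (Rattus norvegicus), read by FLIPR and calcium flux (on this read-out higher numbers stand for an effect only at larger amounts of compound and lower numbers for an effect already at smaller amounts), compound 1 gives 4.1 nM. In this assay, for the measured compounds named here, compound 2 gives 0.4 nM, the lowest of the two numbers; the only neighbour is compound 1, reached by a 10-fold lower number from compound 1 to compound 2 (1.01 log units; beyond the scatter). The structural change in that step is methyl in place of hydrogen on a saturated chain carbon bound to a carbonyl carbon and a saturated chain carbon.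

Compound 3, `COc1ccc(F)c([C@H]2CC[C@H](COc3cccc([C@H](C4CC4)[C@@H](C)C(=O)O)c3)CC2)c1`, has not been measured. Relative to compound 2, (the two compounds have the same atoms and bonds and differ only in configuration as drawn: 1 of 4 stereo elements differ; a stereocentre at a saturated chain carbon is drawn S in compound 2 and R in compound 3). Going by the values given here, no measured step in this set concerns a change of configuration alone; the one step on record, a 10-fold lower number from compound 1 to compound 2 (1.01 log units; beyond the scatter), shows only that the methyl-bearing centre matters, in the drawn S form, to a large degree. Whether the R form keeps that gain is open. A move back toward the number of compound 1, or beyond it, is the expectation rather than a match to compound 2. For compound 3 the expected step is a 20-fold higher number from compound 2 to compound 3 (1.30 log units; beyond the scatter). The estimate for compound 3 in this assay is 8 nM, within 1.5 nM to 45 nM.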

Compound 3, half-maximal effective concentration: 4.9 nM
Estimate against measurement, compound 3: 1.6-fold (0.21 log units) above, within the range that was stated.
By their numbers in this assay, from the lowest: compound 2; then compounds 1 and 3 (each within the scatter of the next).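

In this assay, the configuration of the methyl-bearing saturated chain carbon carries a large step of its own, a 12-fold higher number from compound 2 to compound 3 (1.09 log units; beyond the scatter), and that step can be assigned to this stereocentre alone because of what the two structures show: the fact that compounds 2 and 3 differ only in the configuration as drawn. Methyl on this carbon is therefore not sufficient by itself: with the R configuration the result is a 1.2-fold higher number from compound 1 to compound 3 (0.08 log units; within the scatter). The gain recorded as a 10-fold lower number from compound 1 to compound 2 (1.01 log units; beyond the scatter) thus holds for the S form only, not for methyl at this carbon in general.

Open, on these data alone, is whether an ethyl group or a hydroxyl group on the same carbon would keep that gain in either configuration. Also open, as far as these compounds go, is whether inverting any of the other stereo elements would bring a step of similar size.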